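The compounds below may be only part of what the source reports. "The series", "measured", "known", "first", "only" and "open" are said of these compounds alone.

In a functional assay on KB cells (Homo sapiens), read by MTT assay (a higher number here means a weaker inhibitor, a lower number a stronger inhibitor), compound 1 `CCC#C[C@@]1(O)[C@@H](CO)O[C@@H](n2ccc(N)nc2=O)[C@@H]1O` gives 108000 nM and compound 3 `C=C[C@@]1(O)[C@@H](CO)O[C@@H](n2ccc(N)nc2=O)[C@@H]1O` gives 74300 nM. Compound 2 `C#C[C@@]1(O)[C@H](O)[C@@H](CO)O[C@H]1n1ccc(N)nc1=O` reaches only a limit of this assay, > 350000 nM, so it carries no number (the limit of > 350000 nM in this assay, at which 1 of the 3 values shown sits). Among the two numbers, compound 3 and compound 1 sit within the scatter of each other, as the step of a 1.5-fold lower number from compound 1 to compound 3 (0.16 log units; within the scatter) shows. Compound 4 `CC[C@@]1(O)[C@@H](CO)O[C@@H](n2ccc(N)nc2=O)[C@@H]1O` differs from compound 3 by ethyl in place of vinyl on a saturated ring carbon. For the measured compounds named here, the only measured step at that ring carbon, from but-1-yn-1-yl to vinyl, stayed within the scatter, and the change to ethyl replaces another small chain there; the expected step of a 1.1-fold higher number from compound 3 to compound 4 (0.03 log units; within the scatter) is therefore none beyond the scatter. Compound 4 is estimated at 80000 nM in this assay, within a range from 30000 nM to 250000 nM.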

Compound 4, half-maximal inhibitory concentration: 258000 nM
For compound 4 the middle estimate is 3.2-fold (0.51 log units) below the measured one, and the stated range ends below it.
By their numbers in this assay, from the lowest: compounds 3 and 1 (each within the scatter of the next); then compound 4. At a limit, above all of these: compound 2.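

In this assay, this ring carbon now shows a step beyond the scatter, where the earlier pair had shown none: the change gives a 3.5-fold higher number from compound 3 to compound 4 (0.54 log units; beyond the scatter), and against the longer alkyne it gives a 2.4-fold higher number from compound 1 to compound 4 (0.38 log units; beyond the scatter). Both steps are modest, and they set the saturated ethyl chain apart from the two unsaturated chains, which remain within the scatter of each other. Nothing measured here accounts for the difference.

On these data alone, whether a longer saturated chain such as propyl would follow ethyl remains open. So does the effect of an amine or a fluorine at this ring carbon.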